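Ester to amide at the carbonyl carbon: lipophilicity notes

This account rests on a few compounds, and the source may have more. Where it says the series, first, only, none or still open, it means among the compounds named here.

Measured so far:
compound 1 `CCC(C)OC(=O)/C=C(C)/C=C/CC(C)CCCC(C)C` gives 7.69
compound 2 `CCC(C)OC(=O)/C=C(C)/C=C/CC(C)CCCC(C)(C)OC` gives 6.49
compound 3 `CC(/C=C/CC(C)CCCC(C)(C)OC=O)=C\C(=O)OC(C)C` gives 5.4

All three numbers come from a physicochemical assay for lipophilicity; on this read-out lower numbers stand for lower lipophilicity and higher numbers for higher lipophilicity. Compound 2 stands second highest of the three: compound 3 is the nearest neighbour and lies lower, beyond the scatter, while compound 1 lies higher by a margin also beyond the scatter. Among the compounds with values here, the one step that is shared with a single change, a number 1.20 log units lower from compound 1 to compound 2 (beyond the scatter), goes with methoxy in place of hydrogen on a saturated chain carbon bound to three saturated chain carbons; it says nothing directly about the carbonyl end of the chain. Within the data shown here, compound 2 and compound 3 differ in more than one place, so their values show only that compound 3 sits lower.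

Compound 4 `CCNC(=O)/C=C(C)/C=C/CC(C)CCCC(C)(C)OC` is still to be measured in this assay. Its change from compound 2 is ethylamino in place of sec-butoxy on a carbonyl carbon. Among the measured compounds shown here, no measured step covers a swap of sec-butoxycarbonyl to ethylcarbamoyl, so the expectation rests on the loss of two carbons and the exchange of one hydrogen-bond acceptor for one donor. A downward step is expected, larger than the scatter, estimated at a number 1.99 log units lower from compound 2 to compound 4 (beyond the scatter). Compound 4 is therefore expected to give about 4.5, with a likely range from 3.8 to 5.2.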

Compound 4, partition coefficient: 4.04
Estimate against measurement, compound 4: 0.46 log units above; measured number inside the range.
By their numbers in this assay, from the lowest: compound 4; then compound 3; then compound 2; then compound 1.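

In this assay, the carbonyl carbon whose other neighbour is a double-bonded chain carbon now has a single-place step of its own: ethylamino in place of sec-butoxy gives a number 2.45 log units lower from compound 2 to compound 4 (beyond the scatter). Within the data shown here, the only earlier single-place step, a number 1.20 log units lower from compound 1 to compound 2 (beyond the scatter), lay on a saturated chain carbon, so the read-out is now seen to move at both ends of the chain, with the larger number at the carbonyl end. Nothing available explains the size of the new step.

This single swap changes the group from sec-butoxy to ethylamino, so it does not separate the difference in heavy atoms from the exchange of the oxygen link for a nitrogen link with its amide hydrogen; ethoxy and sec-butylamino on the same carbonyl carbon would divide those two parts, and dimethylamino would show the outcome with no amide hydrogen. Also open, going by these compounds, is whether the step from sec-butoxy to ethylamino has the same size on the core of compound 1, where the chain end has hydrogen in place of methoxy.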